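Swapping 2-nitrophenyl for 2-fluorophenyl at an assay limit

A few compounds are considered here, and "the series" means these few. Any claim that something is new, unique, unknown or untested is made for them only; others in the source may bear on it.

Measured in an ADME assay on A549 cells (Homo sapiens) for cytotoxicity, read by MTT assay, with a stated time of 48 h; a higher number here means a weaker inhibitor of growth, a lower number a stronger inhibitor of growth:
Compound 1 `O=C(/C=C\c1ccccc1[N+](=O)[O-])N1N=C(c2ccncc2)OC1c1c[nH]c2ccccc12`: > 30 ug/mL
Compound 2 `Cc1ccc(/C=C\C(=O)N2N=C(c3ccncc3)OC2c2c[nH]c3ccccc23)cc1`: > 30 ug/mL

Compound 1 stands at > 30 ug/mL, which is a limit and not a number. Compound 2 gives > 30 ug/mL, which is also a limit. Together they show (the limit of > 30 ug/mL in this assay, at which 2 of the 2 values shown sit).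

Compound 3 `O=C(/C=C\c1ccccc1F)N1N=C(c2ccncc2)OC1c1c[nH]c2ccccc12` keeps the core of compound 1 and changes one group: fluoro in place of nitro on an aromatic carbon. This is fluoro in place of nitro on an aromatic carbon, ortho to a large group.

Among the compounds with values here, the only measured step is a step that the two limits leave unreadable from compound 1 to compound 2, so it offers no size to carry over. No step beyond the scatter is therefore expected in this assay, in either direction, and another limit is the likeliest report. The estimated change is a step that the limit leaves unreadable from compound 1 to compound 3. For compound 3 the expected value is 40 ug/mL, with an estimated range of 15 ug/mL to 80 ug/mL.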

Compound 3, concentration for 50% growth inhibition: > 30 ug/mL
Compound 3 was reported as a limit (the forecaster's own chance of this, stated with the estimate: 75%); the middle value is on the limit's open side.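

Within the data shown here, compound 1, compound 2 and compound 3 each report only a limit, so no step between them can be read in this assay: the limit of > 30 ug/mL in this assay, at which 3 of the 3 values shown sit. The compounds shown leave open how strongly any of the three inhibits growth, and whether changing the substituted phenyl group matters at all.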